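The source may hold more compounds than are shown below. What is called first, only, known or untested is meant among the compounds shown, and "the series" means these compounds.

Compound 1 `Cc1ccc(-c2c(CNC(C)(C)C)c(C(=O)O)nn2-c2ccccc2)cc1`: 283000 nM
Compound 2 `CC(C)(C)NCc1c(C(=O)O)nn(-c2ccc(Cl)cc2)c1-c1ccc(Cl)cc1`: 84900 nM

Going by the values given here, these are the only two numbers so far in a functional assay on OVCAR-3 cells (Homo sapiens) for inhibition, read by sulforhodamine B assay, with a stated time of 48 h; a lower number here means a stronger inhibitor of growth, a higher number a weaker inhibitor of growth. Compound 2, at 84900 nM, has the lower number and is the stronger inhibitor of growth of the pair. Its gap to compound 1, at 283000 nM, lies beyond the usual scatter of repeated measurements.

Compound 3 `Cc1ccc(-c2c(CNC(C)(C)C)c(C(=O)O)nn2-c2ccc(Cl)cc2)cc1` has not yet been measured. It differs from compound 2 in one place: methyl in place of chloro on an aromatic carbon. In words, this is methyl in place of chloro on an aromatic carbon, para to a large group, so a 4-chlorophenyl becomes a 4-methylphenyl.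

Among the compounds with values here, no measured pair shows this change on its own, so the expectation rests on little. Within the data shown here, the only other number available is the higher one of compound 1 at 283000 nM, which suggests a modest move upward in this assay rather than a downward one. The expected change is a 1.8-fold higher number from compound 2 to compound 3 (0.25 log units; within the scatter), a small step towards weaker inhibition of growth that may not clear the scatter. For compound 3 the estimated value is 150000 nM, with an expected range of 70000 nM to 320000 nM.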

Compound 3, concentration for 50% growth inhibition: > 629000 nM
Compound 3 ended at the assay's limit; the forecaster's own chance of this, stated with the estimate: 10%; middle value at least 4.1-fold (0.62 log units) from the limit.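

For compound 3 the reading in this assay is a limit of the assay and not a number: the limit of > 629000 nM in this assay, at which 1 of the 3 values shown sits.

Even so, this is the first view of the change on its own, and methyl in place of chloro on an aromatic carbon, para to a large group, gives an at least 7.4-fold higher number from compound 2 to compound 3 (0.86 log units; beyond the scatter), so at this place the 4-chlorophenyl of compound 2 inhibits growth clearly better than the 4-methylphenyl. A chloro group does not help wherever it stands, however: chloro in place of hydrogen on a different aromatic ring gives an at least 2.2-fold higher number from compound 1 to compound 3 (0.34 log units; beyond the scatter), a step in the same direction, towards weaker inhibition of growth.

From the compounds shown here alone, with only a limit for compound 3, the true size of both steps stays unknown, and all three compounds remain weak inhibitors in this assay. The compounds shown leave open whether another group at this place, such as fluoro, methoxy or an amine, would match chloro or improve on it, and whether the gain from chloro holds when the carboxylic acid of the shared core is replaced by an amide.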